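The compounds below may be only part of what the source reports. "The series", "measured", "known", "first", "only" and "open" are said of these compounds alone.

Compound 1 `O=C(CCc1ccc(-c2ccccc2)cc1)c1ncc(-c2ccncc2)o1` is measured in an assay for inhibition of Fatty-acid amide hydrolase 1 (Rattus norvegicus) (on this read-out higher numbers stand for weaker inhibition and lower numbers for stronger inhibition), where compound 1 gives 2.3 nM. Among the three numbers known here this is the second highest. Compound 2 `N#Cc1cccc(-c2cnc(C(=O)CCc3ccc(COc4ccccc4)cc3)o2)n1` gives 0.56 nM in this assay, a lower number that lies beyond the usual scatter, while compound 3 `O=C(O)c1cccc(-c2cnc(C(=O)CCc3ccc(-c4ccc(CN5CCCCC5)cc4)cc3)o2)n1` gives 44 nM, a higher number, also beyond the scatter. Neither of those two differs from compound 1 in only one place, so no single step can be read from them.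

Compound 4 `O=C(CCc1ccc(-c2ccccc2)cc1)c1ncc(-c2cccnc2)o1` has not been measured. It differs from compound 1 as follows: pyridin-3-yl in place of pyridin-4-yl on an aromatic carbon. With the same atoms joined differently, only a small shift is expected, if any beyond the scatter. For compound 4 the expected step from compound 1 is a 1.7-fold higher number from compound 1 to compound 4 (0.24 log units; within the scatter), giving an estimate of 4 nM within 1 nM to 16 nM.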

Compound 4, inhibition constant: 1.1 nM
Compound 4: middle estimate off by 3.6-fold (0.56 log units), on the high side, and the stated range covers the measured number.
By their numbers in this assay, from the lowest: compounds 2 and 4 (each within the scatter of the next); then compound 1; then compound 3.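

Replacing pyridin-4-yl with pyridin-3-yl on the aromatic carbon next to the ring oxygen gives a 2.1-fold lower number from compound 1 to compound 4 (0.32 log units; beyond the scatter). This modest step shows that the read-out at this position responds to where the nitrogen sits in the pyridine ring, even with the same atoms and the same counts of donors and acceptors. Nothing available here accounts for this shift. Still open, as far as these compounds go, is how a plain phenyl ring, with no ring nitrogen, would compare at this position. From the compounds shown here alone, whether the same swap gives a similar step with a different side chain also remains unknown.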